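A few compounds are considered here, and "the series" means these few. Any claim that something is new, unique, unknown or untested is made for them only; others in the source may bear on it.

Measured compounds:
Compound 1 `CCOC(=O)C(=CNc1ccc2c(c1)C(Nc1ccc(Cl)cc1)=NS2(=O)=O)C(=O)OCC` gives 2.39
Compound 2 `O=C(Nc1ccc(Cl)cc1)Nc1ccc(OC2=NS(=O)(=O)c3ccccc32)cc1` gives 3.55

In a physicochemical assay for lipophilicity (a higher number here means a more lipophilic compound, a lower number a more polar compound), compound 2 gives 3.55, the higher of the two numbers. Compound 1 gives 2.39, a gap beyond the usual scatter. Compound 3 `O=C(Nc1ccc(Br)cc1)Nc1ccc(OC2=NS(=O)(=O)c3ccccc32)cc1` differs from compound 2 in one place: bromo in place of chloro on an aromatic carbon. Among the compounds with values here, no measured pair shows this change, so the expectation rests on the change itself; a small rise is expected, not beyond the scatter. For compound 3 the estimate in this assay is 3.75, in a range from 3.45 to 4.05. This amounts to an expected step of a number 0.20 log units higher from compound 2 to compound 3 (within the scatter), within the scatter.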

Compound 3, partition coefficient: 3.64
For compound 3 the middle estimate is 0.11 log units above the measured one; the range from low to high includes it.
By their numbers in this assay, from the lowest: compound 1; then compounds 2 and 3 (each within the scatter of the next).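

Measured by this assay the exchange of chloro for bromo on this aromatic carbon, para to a large group, gives a number 0.09 log units higher from compound 2 to compound 3 (within the scatter) and so leaves the two compounds indistinguishable. Within the data shown here, this is the first one-place comparison, since compound 1 and compound 2 differ in more than one place. No available evidence bears on the reason for this result.

As far as these compounds go, whether a fluoro, a methyl or an amine on the same carbon would stay as close to compound 2 remains open. So does whether this exchange reads the same elsewhere on the molecule.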